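A few compounds are considered here, and "the series" means these few. Any claim that something is new, unique, unknown or untested is made for them only; others in the source may bear on it.

Compound 2 `COc1ccc(/C=N/NC(=O)Nc2ccc(Oc3ccnc(-c4nncn4CCN(C)C)c3)c(F)c2)c(OC)c1OC` and compound 1 `CN(C)CCn1cnnc1-c1cc(Oc2ccc(NC(=O)N/N=C/c3ccc(Cl)cc3Cl)cc2F)ccn1` share one core; they differ only in the aromatic ring attached to the carbon that carries a double bond to nitrogen. Both were looked at in an ADME assay on WI-38 cells (Homo sapiens) for cytotoxicity, read by MTT assay, with a stated time of 72 h; a higher number here means a weaker inhibitor, a lower number a stronger inhibitor. In this assay compound 1 gives 4760 nM, whereas compound 2 gives "not determined" (no result reported), so for compound 2 no single number is available and it cannot be placed on the scale.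

Compound 3 `CN(C)CCn1cnnc1-c1cc(Oc2ccc(NC(=O)N/N=C/c3ccc(F)cc3F)cc2F)ccn1` keeps the same core and is drawn from compound 2 by one swap: 2,4-difluorophenyl in place of 2,3,4-trimethoxyphenyl on a carbon with a double bond to nitrogen. Going by the values given here, with no number for compound 2, the size of this step cannot be fixed from the data; the only anchor is compound 1, whose ring on that carbon carries two chlorines where compound 3 carries two fluorines.

Because compound 1 gives 4760 nM in this assay, compound 3 is expected to land at about 6500 nM, within a range from 2000 nM to 20000 nM.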

Compound 3, half-maximal inhibitory concentration: 5030 nM
Compound 3: middle estimate off by 1.3-fold (0.11 log units), on the high side; the measured number falls inside the stated range.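

In this assay, placing 2,4-difluorophenyl instead of 2,4-dichlorophenyl on a carbon with a double bond to nitrogen gives a 1.1-fold higher number from compound 1 to compound 3 (0.02 log units; within the scatter), so this exchange of two chlorines for two fluorines leaves the read-out within the usual scatter of repeated measurements. Going by these compounds alone, this pair gives the first readable step at this position, and it shows that, for these two compounds, the choice between these two halogens makes no measurable difference to the cell result; the step between compound 2 and compound 3 cannot be read, as compound 2 has no reported result. Nothing shown explains why the two rings read alike.

Going by these compounds, whether a ring carrying 2,3,4-trimethoxyphenyl would read like these two halogen-bearing rings stays open, and two compounds cannot establish a trend for the position. On these data alone, it is also open how a plain phenyl ring, or a phenyl ring carrying a trifluoromethyl group, a nitrile or a carboxylic acid, would read at this same carbon on the shared core.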